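Dichlorophenyl Hydrazone Expected to Remain a Modest Cytotoxin

This account rests on a few compounds, and the source may have more. Where it says the series, first, only, none or still open, it means among the compounds named here.

Measured compounds in an ADME assay on NIH3T3 cells (Mus musculus) for cytotoxicity, read by MTT assay, with a stated time of 24 h; a lower number here means a stronger inhibitor, a higher number a weaker inhibitor:
Compound 1 `C/C(=N\Nc1csc(-c2ccc3c(c2)CCC3)n1)c1ccccc1` gives 200 ug/mL.
Compound 2 `C/C(=N\Nc1csc(-c2ccc3c(c2)CCC3)n1)c1ccc(C)cc1` gives 49 ug/mL.
Compound 3 `C/C(=N\Nc1csc(-c2ccc3c(c2)CCC3)n1)c1ccc([N+](=O)[O-])cc1` gives 90 ug/mL.

Compound 2 has the lowest of the three numbers in this assay, but its gap to compound 3 is within the scatter, so only compound 1 is clearly set apart from it. Compound 4 `C/C(=N\Nc1csc(-c2ccc3c(c2)CCC3)n1)c1ccc(Cl)c(Cl)c1` differs from compound 2 in one place: 3,4-dichlorophenyl in place of 4-methylphenyl on a carbon with a double bond to nitrogen. For the measured compounds named here, the steps that bear on this change are a 4.1-fold lower number from compound 1 to compound 2 (0.61 log units; beyond the scatter) and a 2.2-fold lower number from compound 1 to compound 3 (0.35 log units; beyond the scatter), both showing that a substituted phenyl gives a lower number than the bare ring, while a 1.8-fold higher number from compound 2 to compound 3 (0.26 log units; within the scatter) shows two substituents sitting within the scatter of each other. Compound 4 is therefore expected to stay close to compound 2, with a step of a 1.2-fold lower number from compound 2 to compound 4 (0.09 log units; within the scatter), and its estimate is 40 ug/mL within a range of 15 ug/mL to 120 ug/mL.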

Compound 4, half-maximal inhibitory concentration: 110 ug/mL
Compound 4: the middle estimate sits 2.8-fold (0.44 log units) below what was measured, and the stated range covers the measured number.
By their numbers in this assay, from the lowest: compounds 2, 3, 4 and 1 (each within the scatter of the next, the first and the last beyond it).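

On the carbon with a double bond to nitrogen, 3,4-dichlorophenyl in place of 4-methylphenyl gives a 2.2-fold higher number from compound 2 to compound 4 (0.35 log units; beyond the scatter) in this assay, so these two substituted rings are not interchangeable here. The dichlorophenyl ring stays within the scatter of 4-nitrophenyl, with a 1.2-fold higher number from compound 3 to compound 4 (0.09 log units; within the scatter), and also of bare phenyl, with a 1.8-fold lower number from compound 1 to compound 4 (0.26 log units; within the scatter), so substitution no longer always sets a ring apart from phenyl, as it did with the methyl and nitro groups. Nothing available explains this step. On these data alone, whether 4-chlorophenyl, or a phenyl carrying an amine or a carboxylic acid, would sit nearer compound 2 or compound 1 remains open.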